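The source may report more compounds than this note shows. Statements on the series, on what has been measured and on what is new or still open speak of the compounds shown alone.

Measured in an ADME assay on MDBK cells (Bos taurus) for cytotoxicity, read by MTT assay; on this read-out higher numbers stand for lower toxicity in this test and lower numbers for higher toxicity in this test:
compound 1 `CC1CC(OCCCCCCN2C[C@H](O)[C@@H](O)[C@H](O)[C@H]2CO)CC(C)(C)C1` gives 250000 nM.
compound 2 `OC[C@@H]1[C@@H](O)[C@H](O)[C@@H](O)CN1CCCCCCOc1ccc(C(F)(F)F)cc1` reaches only the assay limit, > 500000 nM.
compound 3 `COc1ccc(OCCCCCCN2C[C@H](O)[C@@H](O)[C@H](O)[C@H]2CO)cc1` also reaches only the assay limit, > 500000 nM.

Compound 3 thus stands at the limit and not at a number; (the limit of > 500000 nM in this assay, at which 2 of the 3 values shown sit), and compound 1 alone carries a measured number. The change to compound 4 `CCCC1CCCCC1OCCCCCCN1C[C@H](O)[C@@H](O)[C@H](O)[C@H]1CO` is a group of 9 heavy atoms (9 carbon; one six-membered non-aromatic ring of carbon only) in place of a group of 8 heavy atoms (7 carbon, 1 oxygen; one six-membered aromatic ring of carbon only), on an oxygen on a saturated carbon. Within the data shown here, two measured steps touch compound 3. The step of an at least 2.0-fold higher number from compound 1 to compound 3 (0.30 log units; that floor lies within the scatter) runs from a non-aromatic ring on that oxygen up toward the limit, its floor within the scatter. The step that the two limits leave unreadable from compound 2 to compound 3 varies only the group on the aromatic ring and says nothing about exchanging the ring itself. Compound 4 reverses the direction of an at least 2.0-fold higher number from compound 1 to compound 3 (0.30 log units; that floor lies within the scatter), putting a non-aromatic ring on the oxygen again as in compound 1, so the expectation is a move back toward the number of compound 1 and away from the limit. The expected step is therefore an at least 2.0-fold lower number from compound 3 to compound 4 (0.30 log units; that floor lies within the scatter), downward, of a size no better resolved than the measured floor allows. Compound 4 is estimated at 250000 nM in this assay, from 120000 nM to 500000 nM, with a fair chance that it too ends only as a limit.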

Compound 4, half-maximal cytotoxic concentration: 150000 nM
For compound 4 the middle estimate is 1.7-fold (0.22 log units) above the measured one; the measured number falls inside the stated range.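

In this assay, among these compounds, replacing the 4-methoxyphenyl on this oxygen with a non-aromatic ring gives an at least 3.3-fold lower number from compound 3 to compound 4 (0.52 log units; beyond the scatter), the first change here whose floor clears the scatter. The two groups carrying a six-membered non-aromatic ring cannot be told apart, since their comparison gives a 1.7-fold lower number from compound 1 to compound 4 (0.22 log units; within the scatter), so in these compounds the difference in the ring's substituents does not register while the exchange of the aromatic ring for a non-aromatic one does. The true size of the exchange stays unresolved and only its floor is known, because compound 3 stands at a limit and not at a number: the limit of > 500000 nM in this assay, at which 2 of the 4 values shown sit.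

From the compounds shown here alone, whether the separation of the two aromatic compounds from the two non-aromatic ones extends beyond these four remains open, as a pyridine ring, a phenyl ring carrying an amine or a carboxylic acid, or a longer chain in place of the present one could each test it. Going by these compounds, how far compound 3 and compound 2 lie beyond the limit also remains open, so the step that joins them cannot be read.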